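A few compounds are considered here, and "the series" means these few. Any claim that something is new, unique, unknown or untested is made for them only; others in the source may bear on it.

Working notes on the series. Compound 1 `COS(=O)(=O)c1ccc(F)c2ncc(I)cc12` is the methyl ester of the shared core. In an assay for inhibition of methylcytosine dioxygenase TET2 (Homo sapiens), read by mass spectrometry, with stated times of 30 min and 1 h (a higher number here means a weaker inhibitor, a lower number a stronger inhibitor), compound 1 gives > 200000 nM, which is a limit of the assay. Compound 2 `CC(C)OS(=O)(=O)c1ccc(F)c2ncc(I)cc12` differs by isopropyl in place of methyl on an oxygen. In this assay compound 2 gives > 200000 nM, again a limit. The step that the two limits leave unreadable from compound 1 to compound 2 therefore cannot be read, since the limit of > 200000 nM in this assay, at which 2 of the 2 values shown sit, holds for both values, and compound 2 stands at that limit with no numerical value of its own.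

Compound 3 `CNS(=O)(=O)c1ccc(F)c2ncc(I)cc12` is the next member, differing from compound 2 by methylamino in place of isopropoxy on a sulfonyl sulfur. For the measured compounds named here, no measured step bears on this change; the one step recorded, a step that the two limits leave unreadable from compound 1 to compound 2, is unreadable, so no direction beyond the scatter can be expected in this assay. Compound 3 is estimated at 200000 nM in this assay, within 30000 nM to 1000000 nM, a step of a number no higher from compound 2 to compound 3 (the limit leaves the size open) that is expected only because compound 2 sits at the limit > 200000 nM.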

Compound 3, half-maximal inhibitory concentration: > 200000 nM
Compound 3 ended at the assay's limit (the forecaster's own chance of this, stated with the estimate: 70%); the middle value lies on the limit itself.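

No new step can be read among compound 1, compound 2 and compound 3, since all three sit at one limit: the limit of > 200000 nM in this assay, at which 3 of the 3 values shown sit.

The compounds shown leave open how methoxy, isopropoxy and methylamino on a sulfonyl sulfur rank against one another in this assay.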